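Swapping the Amide Side Chain on a Tricyclic Core

The source may report more compounds than this note shows. Statements on the series, on what has been measured and on what is new or still open speak of the compounds shown alone.

Compound 3 `CN(C)C(=O)CNC(=O)c1cn(Cc2ccc(-n3cccn3)cc2)c2cccnc12` gives 9.3 mL/min/kg in an ADME assay on liver for metabolic stability, with Liver microsome (Homo sapiens) as the target, using microsomes (a higher number here means faster removal of the compound, a lower number slower removal), the lowest of the three numbers measured, with compound 1 `O=C(N[C@H]1CCCC[C@@H]1O)c1nn(Cc2ccc(-n3cccn3)cc2)c2cccnc12` close by at 9.6 mL/min/kg and compound 2 `O=C(NC[C@@H]1CCCO1)c1cn(Cc2ccc(-n3cccn3)cc2)c2cccnc12` far higher at 133 mL/min/kg. Compound 4 `O=C(N[C@H]1CCCC[C@@H]1O)c1cn(Cc2ccc(-n3cccn3)cc2)c2cccnc12` is reached through the change (2-hydroxycyclohexyl in place of (dimethylcarbamoyl)methyl on an amide-type nitrogen). Among the measured compounds shown here, the only measured step touching this part of the molecule is a 14-fold lower number from compound 2 to compound 3 (1.16 log units; beyond the scatter), which shows that what hangs on the amide nitrogen can move the clearance a lot. Compound 1 carries the same 2-hydroxycyclohexyl group on a different core and sits near compound 3. Compound 4 is therefore expected to show a 1.5-fold higher number from compound 3 to compound 4 (0.18 log units; within the scatter), with an estimate of 14 mL/min/kg and a range of 6 mL/min/kg to 40 mL/min/kg.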

Compound 4, clearance: 59 mL/min/kg
For compound 4 the middle estimate is 4.2-fold (0.62 log units) below the measured one, outside the stated range (above it).
By their numbers in this assay, from the lowest: compounds 3 and 1 (each within the scatter of the next); then compound 4; then compound 2.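

With the core held fixed, 2-hydroxycyclohexyl gives a 6.3-fold higher number from compound 3 to compound 4 (0.80 log units; beyond the scatter) and a 2.3-fold lower number from compound 2 to compound 4 (0.35 log units; beyond the scatter) in this assay so it ranks in the middle of the three side chains on that core. The group alone does not settle the number: compound 1, with the same group on a different core, gives 9.6 mL/min/kg while compound 4 gives 59 mL/min/kg on this one. Nothing available explains these differences. Still open, from the compounds shown here alone, is how a plain cyclohexyl or a chain ending in an amine or a carboxylic acid would read on the shared core, and what (dimethylcarbamoyl)methyl gives on the core of compound 1.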